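The compounds below may be only part of what the source reports. "The series", "measured", "known", "first", "only" and "open" are said of these compounds alone.

Compound 1 `O=C(NO)c1ccc(/C=C/c2ccnc(-c3cccc(O)c3)c2)cc1`: 1610 nM
Compound 2 `Cc1ccc(-c2cc(/C=C/c3ccc(C(=O)NO)cc3)ccn2)cc1`: 2390 nM
Compound 3 `Cc1ccc(-c2cc(/C=C/c3ccc(C(=O)NO)cc3)ccn2)c(F)c1`: not yet measured

In a functional assay on HCT-116 cells (Homo sapiens) for antiproliferative activity, read by CellTiter-Glo, with a stated time of 72 h (a higher number here means a weaker inhibitor, a lower number a stronger inhibitor), compound 2 gives 2390 nM. Among the measured compounds shown here, only one other number stands near it, and the step that connects them, a 1.5-fold higher number from compound 1 to compound 2 (0.17 log units; within the scatter), stays within the scatter, so the two values cannot be told apart.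

Compound 3 is made from compound 2 by one small change: fluoro in place of hydrogen on an aromatic carbon. This is fluoro in place of hydrogen on an aromatic carbon, turning 4-methylphenyl into 2-fluoro-4-methylphenyl.

For the measured compounds named here, no measured step adds a fluoro group, so the data offer no direct guide. Going by the values given here, the one measured step, a 1.5-fold higher number from compound 1 to compound 2 (0.17 log units; within the scatter), altered this same aryl group and stayed small, so no shift beyond the scatter is expected. The expected step is a 1.1-fold lower number from compound 2 to compound 3 (0.04 log units; within the scatter). The estimated value for compound 3 is 2200 nM, with an expected range of 900 nM to 5000 nM.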

Compound 3, half-maximal inhibitory concentration: 800 nM
Estimate against measurement, compound 3: 2.8-fold (0.44 log units) above, and the stated range ends above it.
By their numbers in this assay, from the lowest: compounds 3, 1 and 2 (each within the scatter of the next, the first and the last beyond it).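

In this assay, adding one fluoro to the 4-methylphenyl group gives a 3.0-fold lower number from compound 2 to compound 3 (0.48 log units; beyond the scatter), the only step among these compounds that passes beyond the scatter, so a change of a single heavy atom on this aryl group can be read in this assay. The comparison with the hydroxylated analogue, a 2.0-fold lower number from compound 1 to compound 3 (0.30 log units; within the scatter), stays within the scatter, so the 2-fluoro-4-methylphenyl group of compound 3 and the 3-hydroxyphenyl group of compound 1 cannot be told apart here. Nothing available explains why the fluoro changes the number.

On these data alone, it remains open whether this shift is specific to fluoro or would also follow from another group at the same carbon, ortho to a large group, such as chloro, methoxy or an amine. As far as these compounds go, it is also open whether fluoro would shift the number in the same way on the 3-hydroxyphenyl group of compound 1.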